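Butyl in Place of Allyl on the Shared Core

This account rests on a few compounds, and the source may have more. Where it says the series, first, only, none or still open, it means among the compounds named here.

Compound 1, `C=CCNC(=C\C(=O)/C=C/c1ccc(O)c(OC)c1)/C=C/c1ccc(O)c(OC)c1`: > 25000 nM
Compound 2, `COc1cc(/C=C/C(=O)/C=C(/C=C/c2ccc(OC(C)=O)c(OC)c2)NC2CCCCC2)ccc1OC(C)=O`: > 25000 nM
Compound 3, `CC(C)CNC(=C\C(=O)/C=C/c1ccc(O)cc1)/C=C/c1ccc(O)cc1`: > 25000 nM

In an ADME assay on EA.hy 926 cells (Homo sapiens) for inhibition, read by sulforhodamine B assay, with a stated time of 72 h (a higher number here means a weaker inhibitor, a lower number a stronger inhibitor), compound 1 gives > 25000 nM, which is a limit of the assay and not a measured number. Compound 2 returns the same limit in this assay. Compound 3 returns that limit as well. Across the whole set, (the limit of > 25000 nM in this assay, at which 3 of the 3 values shown sit), so no compound here stands apart from another, and nothing can be said about the order of the three.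

Compound 4, `CCCCNC(=C\C(=O)/C=C/c1ccc(O)c(OC)c1)/C=C/c1ccc(O)c(OC)c1`, has not yet been measured in this assay. It differs from compound 1 by propyl in place of vinyl on a saturated chain carbon bound to an amine nitrogen. Among the compounds with values here, no step between measured compounds exists to set a scale for this change, and all three measured values are limits. The step from compound 1 to compound 4 is therefore expected to be a step that the limit leaves unreadable from compound 1 to compound 4, with no shift beyond the scatter in either direction. Compound 4 is thus expected to give about 30000 nM in this assay, with a range from 12000 nM to 80000 nM, and most probably the assay will again report only a limit.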

Compound 4, half-maximal inhibitory concentration: > 25000 nM
Compound 4: no number, only a limit; the forecaster's own chance of this, stated with the estimate: 80%; the middle value is on the limit's open side.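

In this assay compound 4 gives > 25000 nM, which is a limit of the assay and not a number. Within the data shown here, compound 1 also stands at a limit, so no step from allyl to butyl can be read between compound 1 and compound 4. The compounds shown leave open whether any change on the shared core shifts the result in this assay: the limit of > 25000 nM in this assay, at which 4 of the 4 values shown sit.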